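A few compounds are considered here, and "the series" means these few. Any claim that something is new, unique, unknown or untested is made for them only; others in the source may bear on it.

Working notes on the series. The shared core is kept throughout and only the aryl group on a carbon with a double bond to nitrogen is varied. Compound 1 `COc1ccc(/C=N/NC(=O)Nc2ccc(Oc3ccnc(-c4nncn4CCN(C)C)c3)c(F)c2)c(OC)c1OC` gives 1790 nM in a functional assay on NCI-H460 cells (Homo sapiens) for cytotoxicity, read by MTT assay, with a stated time of 72 h; on this read-out higher numbers stand for weaker inhibition and lower numbers for stronger inhibition. Compound 2 `CN(C)CCn1cnnc1-c1cc(Oc2ccc(NC(=O)N/N=C/c3ccccc3)cc2F)ccn1` gives 1780 nM in this assay, and a 1.0-fold lower number from compound 1 to compound 2 (0.00 log units; within the scatter). Compound 3 `CN(C)CCn1cnnc1-c1cc(Oc2ccc(NC(=O)N/N=C/c3ccc(O)c(O)c3)cc2F)ccn1` gives 1930 nM in this assay. Its steps from the others are a 1.1-fold higher number from compound 1 to compound 3 (0.03 log units; within the scatter) and a 1.1-fold higher number from compound 2 to compound 3 (0.04 log units; within the scatter), so compound 3 sits together with compound 1 and compound 2, none of the three separated beyond the scatter.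

Compound 4 `CN(C)CCn1cnnc1-c1cc(Oc2ccc(NC(=O)N/N=C/c3c(O)ccc4ccccc34)cc2F)ccn1` is not yet measured. The change is 2-hydroxynaphthalen-1-yl in place of 3,4-dihydroxyphenyl on a carbon with a double bond to nitrogen. Among the compounds with values here, the steps that bear on it are those at the same place: a 1.1-fold higher number from compound 1 to compound 3 (0.03 log units; within the scatter) and a 1.1-fold higher number from compound 2 to compound 3 (0.04 log units; within the scatter), and likewise a 1.0-fold lower number from compound 1 to compound 2 (0.00 log units; within the scatter). Three different aryl groups at this position have not moved the number beyond the scatter, so no step beyond the scatter is expected for compound 4, the expected step being a 1.0-fold lower number from compound 3 to compound 4 (0.01 log units; within the scatter). Compound 4 is estimated at 1900 nM, with a range from 900 nM to 4000 nM.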

Compound 4, half-maximal inhibitory concentration: 890 nM
Estimate against measurement, compound 4: 2.1-fold (0.33 log units) above, outside the stated range (below it).
By their numbers in this assay, from the lowest: compounds 4, 2, 1 and 3 (each within the scatter of the next, the first and the last beyond it).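

Within the data shown here, the position is less flat than the first three aryl groups suggested: in this assay there is a 2.2-fold lower number from compound 3 to compound 4 (0.34 log units; beyond the scatter) and this is the first step beyond the scatter, though a modest one. Against the other two aryl groups, 2-hydroxynaphthalen-1-yl stays within the scatter, with a 2.0-fold lower number from compound 2 to compound 4 (0.30 log units; within the scatter) and with a 2.0-fold lower number from compound 1 to compound 4 (0.30 log units; within the scatter) so the separation holds for one pair only and compound 4 cannot be called the most potent of the series. No measurement at hand explains the step, and the data do not separate the contribution of the second aromatic ring from that of the hydroxyl.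

Open, as far as these compounds go, is whether a naphthalene group carrying no hydroxyl would give a number like that of compound 4. Also open, from the compounds shown here alone, is how an amine or a carboxylic acid on the aryl group would read in this assay at this position.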